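The compounds below may be only part of what the source reports. "The series", "measured", "known", "first", "only" and "open" are said of these compounds alone.

Compound 1 `O=C(Nc1cccc(-c2oc3cc(-c4ccc(F)cc4)ccc3c(=O)c2O)c1)c1ccc(F)cc1F` and compound 2 `Cc1cc(C(=O)Nc2cccc(-c3oc4cc(-c5ccc(F)cc5)ccc4c(=O)c3O)c2)ccc1F` share one core and differ only in the aryl group on the carbonyl carbon. In a functional assay on HCC1937 cells (Homo sapiens) for antiproliferative activity, read by CCK-8 assay, with a stated time of 72 h (a higher number here means a weaker inhibitor, a lower number a stronger inhibitor), compound 1 gives 6980 nM, while compound 2 gives 5420 nM. Within the data shown here, the step of a 1.3-fold lower number from compound 1 to compound 2 (0.11 log units; within the scatter) is the only measured comparison, and compound 2 holds the lower of the two numbers, though the gap to compound 1 lies within the scatter. Compound 3 `CCCc1ccc(C(=O)Nc2cccc(-c3oc4cc(-c5ccc(F)cc5)ccc4c(=O)c3O)c2)cc1` continues from compound 2 with the change (4-propylphenyl in place of 4-fluoro-3-methylphenyl on a carbonyl carbon). Among the measured compounds shown here, the one step that bears on this, from compound 1 to compound 2, was small and within the scatter, so a swap of the aryl group on the carbonyl carbon has so far moved the number little. For the measured compounds named here, no measured step tests a propyl chain, so compound 3 is expected to land close to compound 2, with the step of a 1.1-fold lower number from compound 2 to compound 3 (0.04 log units; within the scatter) expected to stay inside the scatter. Compound 3 is therefore estimated at 5000 nM, in a range from 2000 nM to 12000 nM.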

Compound 3, half-maximal inhibitory concentration: 15400 nM
The estimate for compound 3 lay 3.1-fold (0.49 log units) below the measured number; measured number outside the range, above it.
By their numbers in this assay, from the lowest: compounds 2 and 1 (each within the scatter of the next); then compound 3.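

In this assay, the aryl group on the carbonyl carbon proves able to move the number: 4-propylphenyl gives a 2.8-fold higher number from compound 2 to compound 3 (0.45 log units; beyond the scatter) when it replaces 4-fluoro-3-methylphenyl and a 2.2-fold higher number from compound 1 to compound 3 (0.34 log units; beyond the scatter) when it replaces 2,4-difluorophenyl. Among these compounds, both steps lie beyond the scatter and are modest, whereas the one earlier swap at this position stayed within it, so compound 3 is the weakest inhibitor of the three. Nothing measured here gives a reason for this shift.

Compound 3 both carries the propyl chain and has no fluorine on this aryl group, and the compounds shown do not separate these two differences. Going by these compounds, how an ethyl chain, a butyl chain or an amine on this aryl group would read also remains open.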